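The source may report more compounds than this note shows. Statements on the series, on what has been measured and on what is new or still open speak of the compounds shown alone.

Within the data shown here, in a functional assay on SK-BR-3 cells (Homo sapiens) for cytotoxicity, read by MTT assay, with a stated time of 72 h (a lower number here means a stronger inhibitor, a higher number a weaker inhibitor), compound 1 `N[C@H]1CC[C@H](Nc2c(C(=O)NCc3ccc(F)cc3)nc(Br)c3cccnc23)CC1` gives 2000 nM, the only exact number so far. Compound 2 `N[C@H]1CC[C@H](Nc2c(C(=O)NCc3ccc(F)cc3)nc(N3CCCCC3)c3cccnc23)CC1` reads > 10000 nM, which is a limit and not a number. Compound 3 `N[C@H]1CC[C@H](Nc2c(C(=O)NCc3ccccn3)nc(Br)c3cccnc23)CC1` has the entry "not determined" (no result reported) and offers no comparison.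

Compound 4 `COC(=O)CNc1c(C(=O)NCc2ccc(F)cc2)nc(Br)c2cccnc12` keeps the bromo group of compound 1 and carries a different group on the nitrogen: (methoxycarbonyl)methyl in place of 4-aminocyclohexyl on a nitrogen on an aromatic ring. The 4-aminocyclohexyl group and its two defined stereocentres are gone, and the open (methoxycarbonyl)methyl chain stands in their place.

Among the measured compounds shown here, the one measured step is an at least 5.0-fold higher number from compound 1 to compound 2 (0.69 log units; beyond the scatter). It replaces bromo rather than the 4-aminocyclohexyl group, so it bears on this change only indirectly, and it ends at a limit, as the limit of > 10000 nM in this assay, at which 1 of the 3 values shown sits, records. For the measured compounds named here, no measured step touches the group being replaced, so the forecast is loosely grounded. A modest move towards a higher number in this assay is expected, and a reading that gives only a limit remains possible. The expected size is a 3.0-fold higher number from compound 1 to compound 4 (0.48 log units; beyond the scatter). Compound 4 is estimated at 6000 nM, with an expected range of 1800 nM to 20000 nM.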

Compound 4, half-maximal inhibitory concentration: 1000 nM
Compound 4: middle estimate off by 6.0-fold (0.78 log units), on the high side; the measured number lies below the stated range.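

Among these compounds, the step at this nitrogen, a 2.0-fold lower number from compound 1 to compound 4 (0.30 log units; within the scatter), is the first measured change at this place, and it leaves the two compounds level in this assay. With the bromo group held, the 4-aminocyclohexyl group, with its carbon ring and defined stereocentres, is thus not needed for a reading of this order, since the open (methoxycarbonyl)methyl chain serves equally in this pair. Compound 2 remains the only entry that is a limit and not a number: the limit of > 10000 nM in this assay, at which 1 of the 4 values shown sits.

On these data alone, this place rests on a single pair, so it stays open whether the carboxylic acid of the ester, a longer chain or a chain ending in a primary amine would read differently. Also open, as far as these compounds go, is whether piperidin-1-yl in place of bromo gives the same move with the (methoxycarbonyl)methyl chain on the nitrogen.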